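A few compounds are considered here, and "the series" means these few. Any claim that something is new, unique, unknown or untested is made for them only; others in the source may bear on it.

In a functional assay on V79 cells (Cricetulus griseus) for cytotoxicity, read by colony formation (on this read-out lower numbers stand for stronger inhibition and higher numbers for weaker inhibition), compound 1 (`CNCC1(C)CCN(c2c(F)cc3c(=O)c(C(=O)O)cn(C4CC4)c3c2F)C1`) reads 8 ug/mL and compound 2 (`CNCC1(C)CCN(c2c(F)cc3c(=O)c(C(=O)O)cn(C4CC4)c3c2OC)C1`) reads 120 ug/mL while compound 3 (`CNCC1(C)CCN(c2c(F)cc3c(=O)c(C(=O)O)cn(C4CC4)c3c2C(F)(F)F)C1`) reads 230 ug/mL on the same scale. Compound 2 stands with compound 3 and apart from compound 1: the step of a 1.9-fold higher number from compound 2 to compound 3 (0.28 log units; within the scatter) stays within the scatter, while a 15-fold higher number from compound 1 to compound 2 (1.18 log units; beyond the scatter) is large. Compound 4 (`COc1c(N2CCC(C)(N)C2)c(F)cc2c(=O)c(C(=O)O)cn(C3CC3)c12`) keeps the methoxy, and the change is amino in place of (methylamino)methyl on a saturated ring carbon with amino in place of (methylamino)methyl on a saturated ring carbon. The measured steps, including the large 29-fold higher number from compound 1 to compound 3 (1.46 log units; beyond the scatter) as well, are all changes on an aromatic carbon, so none of them bears directly on this change. Among the compounds with values here, the series holds no measured step at the saturated ring carbon. In this assay, going by these compounds, no step beyond the scatter is therefore expected, and the direction stays open. The estimated move is a 1.7-fold lower number from compound 2 to compound 4 (0.23 log units; within the scatter) and carries wide uncertainty. The estimate for compound 4 is 70 ug/mL within an expected range of 15 ug/mL to 250 ug/mL on this read-out.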

Compound 4, half-maximal inhibitory concentration: 38 ug/mL
Estimate against measurement, compound 4: 1.8-fold (0.27 log units) above, and the stated range covers the measured number.
By their numbers in this assay, from the lowest: compound 1; then compound 4; then compounds 2 and 3 (each within the scatter of the next).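

In this assay, amino in place of (methylamino)methyl on the saturated ring carbon gives a 3.2-fold lower number from compound 2 to compound 4 (0.50 log units; beyond the scatter), so the read-out also responds at this ring carbon, two ring bonds from the ring nitrogen, and not only on the aromatic carbon, although this step is modest where the aromatic fluoro replacements are large. The two groups match in hydrogen-bond donors, hydrogen-bond acceptors and net charge, so those counts do not separate them; they differ in heavy atoms. No available evidence accounts for the step.

The compounds shown do not tell whether the same step holds with fluoro or trifluoromethyl on the aromatic carbon. An aminomethyl group at the saturated ring carbon would separate the contribution of the chain carbon from that of the methyl on nitrogen, which this single change alters together.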